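The source may hold more compounds than are shown below. What is called first, only, known or untested is meant among the compounds shown, and "the series" means these compounds.

Measured so far in an ADME assay on liver for metabolic stability, with Liver microsome (Homo sapiens) as the target, using microsomes; on this read-out lower numbers stand for slow clearance and higher numbers for fast clearance:
compound 1 `CN(C)C(=O)CNC(=O)c1cn(Cc2ccc(-n3cccn3)cc2)c2cccnc12` gives 9.3 mL/min/kg
compound 2 `O=C(NC[C@@H]1CCCO1)c1cn(Cc2ccc(-n3cccn3)cc2)c2cccnc12` gives 133 mL/min/kg

Among the compounds with values here, compound 2 stands at the top of these two numbers in this assay, and its only neighbour, compound 1, sits far below it, as the step of a 14-fold higher number from compound 1 to compound 2 (1.16 log units; beyond the scatter) shows. Compound 3 `Cn1ccc(NC(=O)c2cn(Cc3ccc(-n4cccn4)cc3)c3cccnc23)n1` is reached from compound 2 by a single change: 1-methyl-1H-pyrazol-3-yl in place of (oxolan-2-yl)methyl on an amide-type nitrogen. A saturated ring on a one-carbon chain is thus exchanged for an aromatic ring bound straight to the nitrogen of the amide.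

Within the data shown here, only one measured step bears on this change, a 14-fold higher number from compound 1 to compound 2 (1.16 log units; beyond the scatter), and it concerns the same amide nitrogen: there the dimethylcarbamoyl group of compound 1 was exchanged for an oxolan-2-yl group, and the number rose sharply. That step shows that what hangs on this amide can move the number a great deal. Among the measured compounds shown here, the new group in compound 3 again differs from the one in compound 2, and compound 2 already holds the highest number seen, so for compound 3 a downward step in this assay of about a 3.0-fold lower number from compound 2 to compound 3 (0.47 log units; beyond the scatter) is expected, though with wide uncertainty. The estimate for compound 3 is therefore 45 mL/min/kg, within a range from 15 mL/min/kg to 130 mL/min/kg.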

Compound 3, clearance: 31 mL/min/kg
The estimate for compound 3 lay 1.5-fold (0.16 log units) above the measured number, and the stated range covers the measured number.
By their numbers in this assay, from the lowest: compound 1; then compound 3; then compound 2.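

In this assay, putting 1-methyl-1H-pyrazol-3-yl in place of (oxolan-2-yl)methyl on the amide-type nitrogen gives a 4.3-fold lower number from compound 2 to compound 3 (0.63 log units; beyond the scatter) and shows that the high number of compound 2 is not fixed by the shared core. The two groups count the same 6 heavy atoms, so this step goes with a change in the kind of ring and its link to the nitrogen, not with a change in that count, while a 3.3-fold higher number from compound 1 to compound 3 (0.52 log units; beyond the scatter) shows that the new group does not bring the number back down to that of compound 1, whose (dimethylcarbamoyl)methyl group remains the lowest of the three. Nothing measured here says what lies behind these steps.

The aromatic ring and the loss of the one-carbon chain arrive together in one step, so the compounds shown leave open which of the two goes with the lower number. Going by these compounds, an oxolan-3-yl group bound straight to the amide nitrogen, or a 1-methyl-1H-pyrazol-3-ylmethyl group that keeps the one-carbon chain, would pull these two apart, and the effect of an amine or a carboxylic acid on that chain also remains open.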